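Swapping 2-sulfamoylphenyl for pyridin-3-yl on the amide

A few compounds are considered here, and "the series" means these few. Any claim that something is new, unique, unknown or untested is made for them only; others in the source may bear on it.

Three amides built on one shared core have been tested in an ADME assay on LLC-MK2 cells (Macaca mulatta) for cytotoxicity, read by spectrophotometry and crystal violet staining, with a stated time of 4 days; on this read-out higher numbers stand for lower toxicity in this test and lower numbers for higher toxicity in this test. Compound 1 `CC(C)n1ncc2c(C(=O)Nc3c(F)cccc3F)cc(-c3cccs3)nc21` reads > 200000 nM, which is a limit of the assay and not a number. Compound 2 `CC(C)n1ncc2c(C(=O)Nc3cncnc3)cc(-c3cccs3)nc21` gives 20000 nM, and compound 3 `CC(C)n1ncc2c(C(=O)Nc3ccccc3S(N)(=O)=O)cc(-c3cccs3)nc21` gives 25000 nM. These two values sit together, as the measured step is a 1.3-fold higher number from compound 2 to compound 3 (0.10 log units; within the scatter). Compound 3 therefore stands level with compound 2. Both differ clearly from compound 1, with steps of an at least 10-fold lower number from compound 1 to compound 2 (1.00 log units; beyond the scatter) and an at least 8.0-fold lower number from compound 1 to compound 3 (0.90 log units; beyond the scatter).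

Compound 4 `CC(C)n1ncc2c(C(=O)Nc3cccnc3)cc(-c3cccs3)nc21` carries pyridin-3-yl in place of 2-sulfamoylphenyl on an amide-type nitrogen. Within the data shown here, no measured step makes this exact swap, so the guide is compound 2, whose pyrimidin-5-yl is the nearest group to the one entering. Exchanging that group for 2-sulfamoylphenyl gave only a 1.3-fold higher number from compound 2 to compound 3 (0.10 log units; within the scatter), so a large move seems unlikely. The steps away from compound 1 still show that this amide group can matter, which argues for a generous range. In this assay the expected step is no change at the digits printed from compound 3 to compound 4 (within the scatter), which would be no change beyond the scatter. The estimated value for compound 4 is 25000 nM, with an expected range from 10000 nM to 70000 nM.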

Compound 4, half-maximal cytotoxic concentration: > 200000 nM
Compound 4 gave a limit, no number (the forecaster's own chance of this, stated with the estimate: 10%); at least 8.0-fold (0.90 log units) between middle value and limit.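

In this assay, compound 4 gives > 200000 nM, which is a limit of the assay and not a number. The pyridin-3-yl amide does not group with the other two ring amides that carry a reading, with an at least 8.0-fold higher number from compound 3 to compound 4 (0.90 log units; beyond the scatter) and an at least 10-fold higher number from compound 2 to compound 4 (1.00 log units; beyond the scatter), so exchanging one nitrogen-containing aromatic ring for another, pyrimidin-5-yl for pyridin-3-yl, is enough to produce a step beyond the scatter at this amide nitrogen. Compound 1 alone could have suggested that only the 2,6-difluorophenyl group reaches the limit, but compound 4 shows that a ring with a hetero atom can reach it too, while the step between these two cannot be read because both stand at the same limit: the limit of > 200000 nM in this assay, at which 2 of the 4 values shown sit.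

The compounds shown leave open what a plain phenyl or a pyridin-4-yl group on this amide nitrogen would give, and therefore whether the reading follows the pyridin-3-yl ring in particular or a wider family of rings. They also leave open whether an amine or a carboxylic acid added to the pyridin-3-yl ring would keep compound 4 at the limit.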